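This account rests on a few compounds, and the source may have more. Where it says the series, first, only, none or still open, it means among the compounds named here.

Working notes on the series. In a functional assay on PC-3 cells (Homo sapiens) for inhibition, read by sulforhodamine B assay, with a stated time of 48 h, tested at 50 uM (on this read-out higher numbers stand for more inhibition of growth at the one concentration tested and lower numbers for less inhibition of growth), compound 1 (`COc1ccc([C@@H]2C/C(=N/OCc3cn(-c4ccc(C(=O)c5ccccc5)cc4)nn3)c3cc(CC=C(C)C)c(OC)cc3O2)cc1`) gives 40%. That is the lower of the two numbers in hand: compound 2 (`CCOc1ccc([C@@H]2CC(=O)c3cc(CC=C(C)C)c(OC)cc3O2)cc1`) gives 60%, a gap beyond the scatter. The next structure is compound 3 (`COc1ccc([C@@H]2C/C(=N/OCc3cn(-c4ccc(NC(C)=O)cc4)nn3)c3cc(CC=C(C)C)c(OC)cc3O2)cc1`), which carries acetamido in place of benzoyl on an aromatic carbon, para to a large group: acetamido in place of benzoyl on an aromatic carbon. For the measured compounds named here, no measured pair isolates this change, so the two values give no direct size or direction for it. The rest of the structure is unchanged, so the expectation stays anchored on compound 1 at 40%. In this assay no step beyond the scatter is expected, and the estimated step is a number 2 percentage points higher from compound 1 to compound 3 (within the scatter). The estimated value for compound 3 is 42%, with an expected range from 25% to 60%.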

Compound 3, percent growth inhibition at one concentration: 2%
Estimate against measurement, compound 3: 40 percentage points above, and the stated range ends above it.
By their numbers in this assay, from the lowest: compound 3; then compound 1; then compound 2.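

In this assay, acetamido in place of benzoyl on an aromatic carbon, para to a large group, gives a number 38 percentage points lower from compound 1 to compound 3 (beyond the scatter), and compound 3 stands at 2%. For the compounds shown here, this is the only pair that isolates a change at this position, and it shows that growth inhibition at the one concentration tested depends on the group held here: benzoyl, with its six-membered aromatic ring of carbon only, cannot be swapped for acetamido, with no ring, without a large step. Nothing in hand bears on the reason for this step.

The change removes the ring and adds the amide hydrogen together, so the compounds shown do not separate the two. A benzamido group or a plain amine at this place would help to tell them apart.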